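The source may report more compounds than this note shows. Statements on the series, on what has been measured and on what is new or still open speak of the compounds shown alone.

Measured so far in a functional assay on PANC-1 cells (Homo sapiens) for inhibition, read by MTT assay, with a stated time of 72 h; a higher number here means a weaker inhibitor, a lower number a stronger inhibitor:
Compound 1 `O=C(Nc1cc(Cl)cc2cccnc12)c1cnccn1`: 2700 nM
Compound 2 `COc1cc(NC(=O)c2cnccn2)c2ncccc2c1`: 2170 nM

Compound 2, at 2170 nM, stands level with compound 1 within the scatter, and these two are the only reference points. Compound 3 `COc1cc(NC(=O)c2ncccn2)c2ncccc2c1` keeps the core of compound 2 and has pyrimidin-2-yl in place of pyrazin-2-yl on a carbonyl carbon. Among the compounds with values here, the one measured step, a 1.2-fold lower number from compound 1 to compound 2 (0.09 log units; within the scatter), lies within the scatter and is methoxy in place of chloro on an aromatic carbon. It concerns another place in the structure and bears on this change only indirectly. Within the data shown here, no measured step covers the swap itself, so no shift beyond the scatter is expected in this assay, in either direction, and the uncertainty stays wide. The expected step is a 1.2-fold higher number from compound 2 to compound 3 (0.06 log units; within the scatter). For compound 3 the estimate is 2500 nM, with an expected range of 1000 nM to 6500 nM.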

Compound 3, half-maximal inhibitory concentration: 9000 nM
For compound 3 the middle estimate is 3.6-fold (0.56 log units) below the measured one; the whole stated range lies below it.
By their numbers in this assay, from the lowest: compounds 2 and 1 (each within the scatter of the next); then compound 3.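

In this assay, the group on the carbonyl carbon matters: pyrazin-2-yl and pyrimidin-2-yl have the same heavy atoms and the same counts of donors and acceptors, and neither carries a net charge, yet the swap gives a 4.1-fold higher number from compound 2 to compound 3 (0.62 log units; beyond the scatter) in this series. The earlier compounds showed only a change at another place, methoxy in place of chloro on an aromatic carbon, with a 1.2-fold lower number from compound 1 to compound 2 (0.09 log units; within the scatter), so this is the first step shown to go beyond the scatter. Nothing at hand accounts for the difference between these two groups.

The compounds shown leave open whether pyrazin-2-yl is itself favoured or pyrimidin-2-yl alone is disfavoured, as neither pyridin-2-yl nor phenyl stands on this carbonyl carbon among them. On these data alone, it also remains open whether the same swap would have a similar effect with chloro in place of methoxy.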